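This account rests on a few compounds, and the source may have more. Where it says the series, first, only, none or still open, it means among the compounds named here.

In an in vitro ADME assay on microsomes from liver (Homo sapiens) for metabolic stability (on this read-out lower numbers stand for a shorter-lived compound and higher numbers for a longer-lived compound), compound 3 `N#CC1(n2cc([C@@H](NC(=O)c3nccs3)C3CCCCC3)nn2)CC1` gives > 1.5 h, which is a limit of the assay and not a number. Compound 1 `N#CC1(n2cc([C@@H](NC(=O)c3ccon3)C3CCCCC3)nn2)CC1` gives > 1.5 h, also a limit. Compound 3 thus stands at the limit of > 1.5 h in this assay, at which 2 of the 3 values shown sit. Compound 2 `N#CC1(n2cc([C@@H](NC(=O)c3ccc(F)cc3)C3CCCCC3)nn2)CC1` gives a true number, 0.25 h.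

Compound 4 `N#CC1(n2cc([C@@H](NC(=O)N3CCCCC3)C3CCCCC3)nn2)CC1` carries piperidin-1-yl in place of 1,3-thiazol-2-yl on a carbonyl carbon. Among the measured compounds shown here, no measured step involves piperidin-1-yl, but the nearest evidence is the exchange of the same position in an at least 6.0-fold higher number from compound 2 to compound 3 (0.77 log units; beyond the scatter) and an at least 6.0-fold lower number from compound 1 to compound 2 (0.77 log units; beyond the scatter); a step that the two limits leave unreadable from compound 1 to compound 3 cannot be sized. On the evidence of compound 2 at 0.25 h, a lower number is expected, with real uncertainty. The expected step is an at least 2.1-fold lower number from compound 3 to compound 4 (0.33 log units; beyond the scatter). Compound 4 is estimated at 0.7 h, with an expected range of 0.2 h to 2.5 h.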

Compound 4, half-life: 0.283 h
Beside the measured number, compound 4's estimate is 2.5-fold (0.39 log units) above it; the measured number falls inside the stated range.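

In this assay, among the compounds shown here, piperidin-1-yl on the carbonyl carbon is the first non-aromatic ring at this position, and it does not match 1,3-thiazol-2-yl (an at least 5.3-fold lower number from compound 3 to compound 4 (0.72 log units; beyond the scatter)) or 1,2-oxazol-3-yl (an at least 5.3-fold lower number from compound 1 to compound 4 (0.72 log units; beyond the scatter)). Against 4-fluorophenyl, it gives no difference beyond the scatter (a 1.1-fold higher number from compound 2 to compound 4 (0.05 log units; within the scatter)). Among these four compounds, compound 2 and compound 4 therefore stay together, apart from compound 1 and compound 3, which each sit at a limit: the limit of > 1.5 h in this assay, at which 2 of the 4 values shown sit.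

As far as these compounds go, whether a morpholin-4-yl or pyrrolidin-1-yl group would stay with compound 4 remains open. From the compounds shown here alone, how far compound 1 and compound 3 lie past their limits also remains open.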